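Sulfonyl substituent steps: from compound 3 to compound 4

This account rests on a few compounds, and the source may have more. Where it says the series, first, only, none or still open, it means among the compounds named here.

compound 1 `O=C(NCc1ccc(S(=O)(=O)c2cncc(C(F)(F)F)c2)cc1)N1Cc2ccncc2C1`: 10 nM
compound 2 `O=C(NCc1ccc(S(=O)(=O)C2CCOCC2)cc1)N1Cc2ccncc2C1`: 35 nM
compound 3 `O=C(NCc1ccc(S(=O)(=O)N2CCC[C@@H](O)C2)cc1)N1Cc2ccncc2C1`: 70 nM

All three values come from a functional assay on A2780 cells (Homo sapiens) for cytotoxicity, read by sulforhodamine B assay, with a stated time of 72 h; on this read-out lower numbers stand for stronger inhibition and higher numbers for weaker inhibition. In this assay compound 3 gives 70 nM. Its nearest measured comparison is a 2.0-fold higher number from compound 2 to compound 3 (0.30 log units; within the scatter), so these two are not separated. Its furthest is a 7.0-fold higher number from compound 1 to compound 3 (0.85 log units; beyond the scatter).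

Compound 4 `O=C(NCc1ccc(S(=O)(=O)N2CCC(N3CCCC3)CC2)cc1)N1Cc2ccncc2C1` has 4-(pyrrolidin-1-yl)piperidin-1-yl in place of 3-hydroxypiperidin-1-yl on a sulfonyl sulfur.

Among the measured compounds shown here, all the measured steps change the substituent at this same place, so all of them bear on the new change. The other two are a 3.5-fold higher number from compound 1 to compound 2 (0.54 log units; beyond the scatter) and a 7.0-fold higher number from compound 1 to compound 3 (0.85 log units; beyond the scatter), both modest, and the one between the two non-aromatic substituents, a 2.0-fold higher number from compound 2 to compound 3 (0.30 log units; within the scatter), stays within the scatter. For the measured compounds named here, no measured compound carries the entering group, and the data do not fix a direction. Going by the values given here, compound 4 keeps a non-aromatic ring on the sulfonyl sulfur, as compound 3 does at 70 nM, so no step clearly beyond the scatter is expected in this assay. The expected change is a 1.4-fold lower number from compound 3 to compound 4 (0.15 log units; within the scatter), with little confidence in its direction. For compound 4 the estimate is 50 nM, with an expected range of 15 nM to 170 nM.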

Compound 4, half-maximal inhibitory concentration: 5.6 nM
The estimate for compound 4 lay 8.9-fold (0.95 log units) above the measured number, and the stated range ends above it.
By their numbers in this assay, from the lowest: compounds 4 and 1 (each within the scatter of the next); then compounds 2 and 3 (each within the scatter of the next).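

In this assay, the non-aromatic substituents on the sulfonyl sulfur are not interchangeable. Oxan-4-yl and 3-hydroxypiperidin-1-yl had remained within the scatter of each other, but a 13-fold lower number from compound 3 to compound 4 (1.10 log units; beyond the scatter) is a large step and a 6.3-fold lower number from compound 2 to compound 4 (0.80 log units; beyond the scatter) also lies beyond the scatter. An aromatic substituent is also not required to reach the lowest numbers in this set, since a 1.8-fold lower number from compound 1 to compound 4 (0.25 log units; within the scatter) leaves 4-(pyrrolidin-1-yl)piperidin-1-yl and 5-(trifluoromethyl)pyridin-3-yl unseparated, and no measurement at hand accounts for any of these steps.

Still open, as far as these compounds go, is which part of 4-(pyrrolidin-1-yl)piperidin-1-yl carries the step: a 4-(dimethylamino)piperidin-1-yl would test whether the pyrrolidine ring can be replaced by a simple amine, while a 4-cyclopentylpiperidin-1-yl would test whether that ring nitrogen can be replaced by carbon. The entering group also differs from 3-hydroxypiperidin-1-yl by the loss of the hydroxyl. An unsubstituted piperidin-1-yl would be needed to separate the effect of removing that hydroxyl from the effect of adding the pyrrolidine ring.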